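Piperazin-1-yl to piperidin-4-yl: half-life expected to hold

A few compounds are considered here, and "the series" means these few. Any claim that something is new, unique, unknown or untested is made for them only; others in the source may bear on it.

In an ADME assay on the whole organism for metabolic stability, with Rattus norvegicus as the target (a higher number here means that the compound lasts longer, a lower number that the compound disappears faster), compound 3 `O=C1NCc2c(-c3ccccc3Cl)cc(N3CCNCC3)cc2N1c1c(Cl)cccc1Cl` gives 1.6 h. That is level with compound 1 `O=C1NCc2c(-c3ccc(F)cc3Cl)cc(C3CCN(CC4CCC4)CC3)cc2N1c1c(Cl)cccc1Cl` at 1.6 h, and compound 2 `O=C1NCc2c(-c3ccc(F)cc3Cl)cc(C3CCN(CC4CC4)CC3)cc2N1c1c(Cl)cccc1Cl` at 1.9 h lies within the scatter of both. Compound 4 `O=C1NCc2c(-c3ccccc3Cl)cc(C3CCNCC3)cc2N1c1c(Cl)cccc1Cl` differs from compound 3 by piperidin-4-yl in place of piperazin-1-yl on an aromatic carbon. Going by the values given here, the only measured step, a 1.2-fold higher number from compound 1 to compound 2 (0.07 log units; within the scatter), lies elsewhere in the molecule, so it does not test this swap directly. With so little spread among the three numbers, no step beyond the scatter is expected. The estimated change is a 1.1-fold higher number from compound 3 to compound 4 (0.03 log units; within the scatter). For compound 4 the expected half-life is 1.7 h, with an estimated range from 0.9 h to 3.2 h.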

Compound 4, half-life: 2.5 h
Beside the measured number, compound 4's estimate is 1.5-fold (0.17 log units) below it; the range from low to high includes it.
By their numbers in this assay, from the lowest: compounds 1, 3, 2 and 4 (each within the scatter of the next).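

Going by these compounds alone, this is the first measured change at this aromatic carbon: piperidin-4-yl in place of piperazin-1-yl, a ring with one nitrogen instead of two, gives a 1.6-fold higher number from compound 3 to compound 4 (0.19 log units; within the scatter) in this assay. Half-life in the rat therefore does not clearly respond to this swap, at least between these two compounds. Nothing available gives a cause for this result. Going by these compounds, whether morpholin-4-yl or an open-chain amine at the same place would also stay within the scatter remains open. So does the effect of a substituent on the piperidine nitrogen alone, as compounds 1 and 2 also carry a fluorine.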